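Aryl swap on the shared core: compound 2 to compound 3

A few compounds are considered here, and "the series" means these few. Any claim that something is new, unique, unknown or untested is made for them only; others in the source may bear on it.

Measured so far in a physicochemical assay for solubility, read by HPLC, in phosphate buffer, measured as kinetic solubility, at pH 7.4; on this read-out higher numbers stand for higher solubility and lower numbers for lower solubility:
- compound 1 `CCOC(=O)c1cc(-c2ccc(F)cc2)n(-c2ccc(S(N)(=O)=O)cc2)c1C`: 12600 nM
- compound 2 `CCOC(=O)c1cc(-c2ccc(OC)cc2)n(-c2ccc(S(N)(=O)=O)cc2)c1C`: 16100 nM

Compound 2, at 16100 nM, cannot be ranked against compound 1, since the two values lie within the scatter of each other. The next compound to read is compound 3 `CCOC(=O)c1cc(-c2cccc(Cl)c2)n(-c2ccc(S(N)(=O)=O)cc2)c1C`, and the change is 3-chlorophenyl in place of 4-methoxyphenyl on an aromatic carbon. In short, 3-chlorophenyl replaces 4-methoxyphenyl on an aromatic carbon, next to the ring nitrogen.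

Among the measured compounds shown here, one measured step bears on this, a swap of a substituent on the same aryl group: a 1.3-fold higher number from compound 1 to compound 2 (0.11 log units; within the scatter). For the measured compounds named here, no measured compound carries a 3-chlorophenyl group, so the evidence is thin and the range is kept wide. Since that swap gave a 1.3-fold higher number from compound 1 to compound 2 (0.11 log units; within the scatter) no step beyond the scatter is expected in this assay, and no firm direction can be assigned. The expected change is a 1.5-fold lower number from compound 2 to compound 3 (0.17 log units; within the scatter). The estimated value for compound 3 is 11000 nM, with an expected range from 4500 nM to 22000 nM.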

Compound 3, solubility: 9200 nM
Compound 3: middle estimate off by 1.2-fold (0.08 log units), on the high side, within the range that was stated.
By their numbers in this assay, from the lowest: compounds 3, 1 and 2 (each within the scatter of the next).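

In this assay, 3-chlorophenyl in place of 4-methoxyphenyl gives a 1.8-fold lower number from compound 2 to compound 3 (0.24 log units; within the scatter), and 3-chlorophenyl in place of 4-fluorophenyl gives a 1.4-fold lower number from compound 1 to compound 3 (0.14 log units; within the scatter). The earlier step changed only the substituent at the 4 position of the aryl group, whereas these two steps also carry the substituent to the 3 position, and neither leaves the scatter, so compounds 1, 2 and 3 cannot be ranked on this read-out. At this aromatic carbon next to the ring nitrogen, the three aryl groups shown therefore give no resolved difference, and nothing at hand offers an explanation for the values of the three compounds.

The compounds shown leave open whether any group at this position can produce a step beyond the scatter, for example an aryl group bearing an amine or a carboxylic acid, or a longer chain in place of the aryl group. As far as these compounds go, the ethoxycarbonyl and methyl groups are the same in all three compounds, so what a carboxylic acid in place of the ethoxycarbonyl group would do to the read-out also stays open.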